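This account rests on a few compounds, and the source may have more. Where it says the series, first, only, none or still open, it means among the compounds named here.

Going by the values given here, in a functional assay on SH-SY5Y cells (Homo sapiens) for antiproliferative activity, read by MTT assay, with a stated time of 48 h (a lower number here means a stronger inhibitor of growth, a higher number a weaker inhibitor of growth), compound 2 `COc1ccc(N(C)c2ncnc3c2ncn3Cc2cc(OC)c(OC)c(OC)c2)cc1` gives 260 nM, the lowest number of the three measured so far. Compound 3 `COc1ccc(N(C)c2nc(Cl)nc3c2ncn3Cc2cc(OC)c(OC)c(OC)c2)cc1` gives 3000 nM. Compound 1 `COc1ccc(N(C)c2ncnc3c2ncn3Cc2cc(OC)cc(OC)c2)cc1` stands at > 100000 nM, which is a limit of the assay and not a number. Two single changes set these compounds apart. Methoxy in place of hydrogen on an aromatic carbon gives an at least 380-fold lower number from compound 1 to compound 2 (2.58 log units; beyond the scatter). Chloro in place of hydrogen on an aromatic carbon gives a 12-fold higher number from compound 2 to compound 3 (1.06 log units; beyond the scatter).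

Compound 4 `COc1cc(Cn2cnc3c(Cl)ncnc32)cc(OC)c1OC` carries chloro in place of the (4-methoxyphenyl)(methyl)amino group of compound 2, on an aromatic carbon: chloro in place of (4-methoxyphenyl)(methyl)amino on an aromatic carbon. Among the compounds with values here, no measured step removes this group, so the support is indirect. Both measured steps were large, which shows that compound 2 loses much of its effect after a single change, and this change is far bigger than either. A large move to a higher number is therefore expected, an estimated 77-fold higher number from compound 2 to compound 4 (1.89 log units; beyond the scatter). For compound 4 the estimate is 20000 nM, with an expected range from 3000 nM to 100000 nM.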

Compound 4, concentration for 50% growth inhibition: > 100000 nM
Compound 4: no number, only a limit (the forecaster's own chance of this, stated with the estimate: 35%); middle value at least 5.0-fold (0.69 log units) away from the limit.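

In this assay, chloro in place of (4-methoxyphenyl)(methyl)amino, on the aromatic carbon next to the ring nitrogen, gives an at least 380-fold higher number from compound 2 to compound 4 (2.58 log units; beyond the scatter). The value of compound 4, > 100000 nM, is a limit of the assay and not a number. The earlier steps shown here all kept this group, whereas compound 4 keeps the methoxy group whose addition marked the step to compound 2, so this methoxy group alone does not give a measurable effect on growth here.

On these data alone, how much of a loss this change really causes cannot be read, because the read-out stops at a limit: the limit of > 100000 nM in this assay, at which 2 of the 4 values shown sit. Also open is whether a simple amine or a methylamino group at this place would keep any of the effect of compound 2.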